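The source may report more compounds than this note shows. Statements on the series, on what has been measured and on what is new or still open speak of the compounds shown alone.

Measured so far:
compound 1 `CCOC(=O)n1nc(N)c(/N=N/c2ccc(O)cc2)c1N` — > 100000 nM (a limit)
compound 2 `Nc1nn(C(=O)c2cccs2)c(N)c1/N=N/c1ccc(O)cc1` — > 25000 nM (a limit)
compound 3 `Cn1nc(N)c(/N=N/c2ccc(O)cc2)c1N` — 98500 nM

Going by the values given here, in a functional assay on K562 cells (Homo sapiens) for cytotoxicity, read by fluorescence, with a stated time of 72 h (on this read-out higher numbers stand for weaker inhibition and lower numbers for stronger inhibition), compound 3 gives 98500 nM, the only number in the set. For compound 1 the value > 100000 nM is a limit of the assay. For compound 2 the value > 25000 nM is likewise a limit. Among the compounds with values here, compound 3 therefore stands as the one analogue with a measured, though weak, inhibition.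

Compound 4 `CC(=O)n1nc(N)c(/N=N/c2ccc(O)cc2)c1N` differs from compound 3 by acetyl in place of methyl on an aromatic nitrogen. The measured steps that touch the same aromatic nitrogen are an at least 1.0-fold lower number from compound 1 to compound 3 (0.00 log units; that floor lies within the scatter) and a step that the limit leaves unreadable from compound 2 to compound 3; both exchange a carbonyl-bearing group for methyl, and neither has a readable size because compound 1 sits at the limit of > 100000 nM in this assay, at which 1 of the 3 values shown sits, and compound 2 at the limit of > 25000 nM in this assay, at which 1 of the 3 values shown sits. Acetyl, like ethoxycarbonyl and (thiophen-2-yl)carbonyl, places a carbonyl on that nitrogen, and both carbonyl-bearing analogues returned only limits.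

For compound 4 the expected step is a 1.1-fold higher number from compound 3 to compound 4 (0.05 log units; within the scatter), from no change beyond the scatter toward a higher number, with a real chance that only a limit is returned. Compound 4 is estimated at 110000 nM, between 45000 nM and 270000 nM.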

Compound 4, half-maximal inhibitory concentration: 64900 nM
Estimate against measurement, compound 4: 1.7-fold (0.23 log units) above; the measured number falls inside the stated range.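

In this assay compound 4 shows that a carbonyl on this aromatic nitrogen can still return a measured number, which the limits of compound 1 and compound 2 could not show. Acetyl in place of methyl gives a 1.5-fold lower number from compound 3 to compound 4 (0.18 log units; within the scatter), so at this position the two groups cannot be told apart in this read-out, and methyl in place of ethoxy on the carbonyl carbon gives an at least 1.5-fold lower number from compound 1 to compound 4 (0.18 log units; that floor lies within the scatter), a floor that separates neither compound from the other. Compound 2 remains only a limit, and its step to compound 4 cannot be read: the limit of > 25000 nM in this assay, at which 1 of the 4 values shown sits.

On these data alone, whether any group on this aromatic nitrogen can move the number beyond the scatter remains open, and a benzoyl group, a longer acyl chain such as butanoyl, or a chain ending in a carboxylic acid would extend the comparison with acetyl. All the compounds shown share the rest of the core, so they say nothing about how the read-out responds to a change elsewhere, such as replacing an amino group on the ring with a dimethylamino group.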